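This account rests on a few compounds, and the source may have more. Where it says the series, first, only, none or still open, it means among the compounds named here.

Compound 1, `COC(=O)c1cccc(NC(=O)c2ccc3ccccc3c2)c1`, gives 5 ug/mL in a physicochemical assay for solubility; on this read-out lower numbers stand for lower solubility and higher numbers for higher solubility.
Compound 2, `COC(=O)c1cccc(NC(=O)c2cc3cc([N+](=O)[O-])ccc3o2)c1`, gives 25 ug/mL in this assay.
Compound 3, `NC(=O)c1cccc(NC(=O)c2ccc3ccccc3c2)c1`, gives only a limit in this assay, < 5 ug/mL.

Compound 1 and compound 3 differ in one place: amino in place of methoxy on a carbonyl carbon. This change produced a number no higher from compound 1 to compound 3 (the limit leaves the size open). The value of compound 3 sits at the limit of < 5 ug/mL in this assay, at which 1 of the 3 values shown sits, so the size of that drop cannot be read. Compound 2 is built on a different core from compound 1, and the difference between the two cores is not broken down here. Compound 4, `NC(=O)c1cccc(NC(=O)c2cc3cc([N+](=O)[O-])ccc3o2)c1`, is not yet measured and carries the same change relative to compound 2: amino in place of methoxy on a carbonyl carbon. The step is expected to run downward, estimated as a 2.5-fold lower number from compound 2 to compound 4 (0.40 log units; beyond the scatter), resting on the measured a number no higher from compound 1 to compound 3 (the limit leaves the size open). Compound 4 is therefore estimated at 10 ug/mL, somewhere between 3 ug/mL and 30 ug/mL.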

Compound 4, solubility: 20 ug/mL
The estimate for compound 4 lay 2.0-fold (0.30 log units) below the measured number, and the stated range covers the measured number.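

In this assay, among the compounds shown here, putting amino in place of methoxy on the carbonyl carbon gives a 1.3-fold lower number from compound 2 to compound 4 (0.10 log units; within the scatter), so on the core of compound 2 this change leaves no step that stands out from the ordinary spread of repeat measurements. The same change on the core of compound 1 cannot be sized, because compound 3 gives only a limit of the assay, not a number: the limit of < 5 ug/mL in this assay, at which 1 of the 4 values shown sits. The two pairs therefore show no readable step beyond the scatter, and they do not show whether the change behaves alike on both cores.

The compounds shown leave open what other groups on this carbonyl carbon would do, such as a carboxylic acid or a methylamino group. They also leave open how the change would read on a third core.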